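Taking the phenyl group off: expectation for compound 3

The source may hold more compounds than are shown below. What is called first, only, known or untested is meant among the compounds shown, and "the series" means these compounds.

Of the compounds shown here, two have numbers so far in a functional assay (aorta) for antagonist activity, with Oryctolagus cuniculus as the target; on this read-out higher numbers stand for weaker inhibition and lower numbers for stronger inhibition. Compound 1 `CCCCc1nc(C)c(C(=O)OCC)c(=O)n1Cc1ccc(-c2ccccc2C(=O)O)cc1` gives 95 nM, and compound 2 `CCCCc1nc(-c2ccccc2)c(C(=O)OCC)c(=O)n1Cc1ccc(-c2ccccc2C(=O)O)cc1` gives 140 nM; the two values lie within the scatter of each other. The next step leads to compound 3 `CCCCc1ncc(C(=O)OCC)c(=O)n1Cc1ccc(-c2ccccc2C(=O)O)cc1`, with hydrogen in place of phenyl on an aromatic carbon. For the measured compounds named here, one measured step bears on this place, the exchange of methyl for phenyl, a 1.5-fold higher number from compound 1 to compound 2 (0.17 log units; within the scatter). Going by the values given here, it stayed within the scatter, but it covers only methyl and phenyl, and no measurement yet shows hydrogen there. On that single step, no change beyond the scatter is expected in this assay, and no direction can be called with confidence. The expected step is a 1.3-fold lower number from compound 2 to compound 3 (0.10 log units; within the scatter). Compound 3 is estimated at 110 nM, with an expected range from 45 nM to 270 nM.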

Compound 3, antagonist equilibrium constant: 610 nM
For compound 3 the middle estimate is 5.5-fold (0.74 log units) below the measured one, outside the stated range (above it).
By their numbers in this assay, from the lowest: compounds 1 and 2 (each within the scatter of the next); then compound 3.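

In this assay, hydrogen on this aromatic carbon separates from both earlier groups, with a 4.4-fold higher number from compound 2 to compound 3 (0.64 log units; beyond the scatter) and a 6.4-fold higher number from compound 1 to compound 3 (0.81 log units; beyond the scatter), both steps beyond the scatter. The exchange of methyl for phenyl alone made this place look indifferent; the series now shows weaker inhibition with hydrogen there, while methyl and phenyl stay within the scatter of each other. Nothing available explains the loss with hydrogen or the tolerance for both methyl and phenyl.

The compounds shown carry only hydrogen, methyl and phenyl at this place, so it remains open whether an amine, a hydroxyl group, chlorine or a longer alkyl chain such as propyl would match methyl and phenyl. Also open, on these data alone, is whether the step to hydrogen keeps its size when the ethoxycarbonyl group gives way to a carboxylic acid.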